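This account rests on a few compounds, and the source may have more. Where it says the series, first, only, none or still open, it means among the compounds named here.

The measured compounds and their results in a functional assay on COLO 205 cells (Homo sapiens) for inhibition, read by sulforhodamine B assay; on this read-out higher numbers stand for weaker inhibition of growth and lower numbers for stronger inhibition of growth:

Compound 1 `COc1ccc(-c2ccc(-c3ccc(-c4nc5cc(C)ccc5[nH]4)cc3)cc2)cc1OC` gives 2320 nM.
Compound 2 `Oc1cccc2[nH]c(-c3ccc(-c4ccc(-c5ccccc5)cc4)cc3)nc12` gives 1210 nM.
Compound 3 `COc1ccc(-c2ccc(-c3ccc(-c4nc5c(O)cccc5[nH]4)cc3)cc2)cc1OC` gives 1320 nM.

All three compounds are built on the same three-ring chain with a benzimidazole at one end, and they differ only at the two ends of that chain. The three numbers lie within the usual scatter of one another, so none of them can be set apart from the others on this read-out.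

Compound 4 `Cc1ccc2[nH]c(-c3ccc(-c4ccc(-c5ccccc5)cc4)cc3)nc2c1` has not yet been measured. It arises from compound 1 by one change: phenyl in place of 3,4-dimethoxyphenyl on an aromatic carbon. Exactly the same change has already been measured once, between compound 3 and compound 2: phenyl in place of 3,4-dimethoxyphenyl on an aromatic carbon. That step was a 1.1-fold lower number from compound 3 to compound 2 (0.04 log units; within the scatter). The two starting points, compound 1 and compound 3, differ in their cores: 5-methyl-1H-benzimidazol-2-yl in place of 4-hydroxy-1H-benzimidazol-2-yl on an aromatic carbon. Between them the step is a 1.8-fold lower number from compound 1 to compound 3 (0.24 log units; within the scatter).

With one measured example of this change giving almost no movement, the step from compound 1 to compound 4 is expected to be small as well, a 1.1-fold lower number from compound 1 to compound 4 (0.04 log units; within the scatter), resting on the step of a 1.1-fold lower number from compound 3 to compound 2 (0.04 log units; within the scatter). Compound 4 is therefore expected to give about 2100 nM in this assay. Allowing for the usual scatter, compound 4 is estimated to fall between 1000 nM and 4500 nM.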

Compound 4, concentration for 50% growth inhibition: 2560 nM
Compound 4: the middle estimate sits 1.2-fold (0.09 log units) below what was measured, and the stated range covers the measured number.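

In this assay, putting phenyl in place of 3,4-dimethoxyphenyl gives a 1.1-fold higher number from compound 1 to compound 4 (0.04 log units; within the scatter) and so leaves the number essentially unmoved on the core of compound 1. Set beside the earlier case, the same change behaves alike on the core carrying 5-methyl-1H-benzimidazol-2-yl and on the core carrying 4-hydroxy-1H-benzimidazol-2-yl: the same change on two cores in this assay, a 1.1-fold lower number (0.04 log units; within the scatter) from compound 3 to compound 2 and a 1.1-fold higher number (0.04 log units; within the scatter) from compound 1 to compound 4, 1.2-fold (0.08 log units) apart, within the scatter of two such steps. This shows that, on these two cores, the change can be carried across with no visible difference in growth inhibition, but it does not show that the agreement would hold on any other core, and since neither step stands out from the scatter, the two pairs test only a change that does almost nothing here, not whether a larger effect would transfer equally well.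

The compounds shown leave open whether any group at this end of the chain can move the number beyond the scatter, for instance a phenyl ring carrying an amine or a carboxylic acid. They also leave open how a longer chain on the benzimidazole would read in this assay, and whether the phenyl swap would stay as quiet on such a core.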